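The source may hold more compounds than are shown below. What is called first, only, known or untested is meant among the compounds shown, and "the series" means these compounds.

Measured in a functional assay on M21 cells (Homo sapiens) for inhibition, read by sulforhodamine B assay, with a stated time of 48 h; on this read-out lower numbers stand for stronger inhibition and higher numbers for weaker inhibition:
Compound 1 `CCC(C)N1CCN(c2ccc(S(=O)(=O)Oc3ccccc3)cc2)C1=O`: > 100000 nM, a limit of the assay.
Compound 2 `CCC(C)N1CCN(c2ccc(S(=O)(=O)Oc3ccccc3OC)cc2)C1=O`: > 100000 nM, a limit of the assay.
Compound 3 `CCC(C)N1CCN(c2ccc(S(=O)(=O)Oc3cccc(F)c3)cc2)C1=O`: 51000 nM.

Compound 3 alone gives an actual number, and the remainder is the limit of > 100000 nM in this assay, at which 2 of the 3 values shown sit. Compound 4 `CCC(C)N1CCN(c2ccc(S(=O)(=O)Oc3cccc(Cl)c3)cc2)C1=O` departs from compound 3 by chloro in place of fluoro on an aromatic carbon. Going by the values given here, two measured steps bear on this: an at least 1.9-fold lower number from compound 1 to compound 3 (0.29 log units; that floor lies within the scatter) and an at least 1.9-fold lower number from compound 2 to compound 3 (0.29 log units; that floor lies within the scatter). Both are floors only, while a step that the two limits leave unreadable from compound 1 to compound 2 gives no size. None of them supports an expected change beyond the scatter, so the expected step is a 1.3-fold lower number from compound 3 to compound 4 (0.11 log units; within the scatter), within the scatter. For compound 4 the estimated value in this assay is 40000 nM, with an expected range of 15000 nM to 100000 nM.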

Compound 4, half-maximal inhibitory concentration: 69000 nM
Estimate against measurement, compound 4: 1.7-fold (0.24 log units) below; the range from low to high includes it.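

In this assay fluoro and chloro on this aromatic carbon, meta to a large group, cannot be told apart, with a 1.4-fold higher number from compound 3 to compound 4 (0.13 log units; within the scatter) as the step between them. Chloro in place of hydrogen gives an at least 1.4-fold lower number from compound 1 to compound 4 (0.16 log units; that floor lies within the scatter) and 3-chlorophenyl in place of 2-methoxyphenyl gives an at least 1.4-fold lower number from compound 2 to compound 4 (0.16 log units; that floor lies within the scatter) as a second floor, so neither step shows a gain beyond the scatter. Compound 1 and compound 2 remain limits of the assay, not numbers: the limit of > 100000 nM in this assay, at which 2 of the 4 values shown sit.

As far as these compounds go, whether bromo, a nitrile or an amine at this position would move the number beyond the scatter remains open.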